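Solubility of a quinoline series: moving from compound 2 to compound 4

A few compounds are considered here, and "the series" means these few. Any claim that something is new, unique, unknown or untested is made for them only; others in the source may bear on it.

Compounds measured so far:
compound 1, `COc1ccccc1Oc1ccc2c(NCCCNCc3ccco3)ccnc2c1`, 14500 nM
compound 2, `COc1ccc(F)cc1CNCCCNc1ccnc2cc(Cc3cc(C)cc(C)c3)ccc12`, 4200 nM
compound 3, `Cc1cc(C)cc(Cc2ccc3c(NCCCNCc4ccco4)ccnc3c2)c1`, 4200 nM

In a physicochemical assay for solubility, with a stated time of 18 h, at pH 7.4 (a lower number here means a less soluble compound, a higher number a more soluble compound), compound 2 stands level with compound 3 at the digits shown, and the two share the lowest number of the three; compound 1 sits furthest away, a change of a 3.5-fold lower number from compound 1 to compound 3 (0.54 log units; beyond the scatter) separating it from compound 3. Compound 4, `COc1ccc(F)cc1CNCCCNc1ccnc2cc(-c3ccc(F)cc3)ccc12`, differs from compound 2 only in one place: 4-fluorophenyl in place of 3,5-dimethylbenzyl on an aromatic carbon. Among the measured compounds shown here, the one measured step at this position, a 3.5-fold lower number from compound 1 to compound 3 (0.54 log units; beyond the scatter), shows that exchanging the group on this aromatic carbon can shift solubility beyond the scatter, and there the arrival of 3,5-dimethylbenzyl went with the lower number. Its departure here is therefore expected to bring a modest rise, a 1.8-fold higher number from compound 2 to compound 4 (0.25 log units; within the scatter). Compound 4 is estimated at 7500 nM, within 3000 nM to 18000 nM.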

Compound 4, solubility: 32000 nM
Estimate against measurement, compound 4: 4.3-fold (0.63 log units) below, and the stated range ends below it.
By their numbers in this assay, from the lowest: compounds 2 and 3 (each within the scatter of the next); then compound 1; then compound 4.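

In this assay, replacing 3,5-dimethylbenzyl with 4-fluorophenyl on this aromatic carbon gives a 7.6-fold higher number from compound 2 to compound 4 (0.88 log units; beyond the scatter). The group at this position therefore moves solubility beyond the scatter with the 5-fluoro-2-methoxyphenyl side chain too, not only with the furan-2-yl side chain of the earlier step. Nothing shown accounts for the size of this step. From the compounds shown here alone, the exchange alters the group's size, ring attachment and substituents at once, so the contribution of each remains open. A plain phenyl or a 4-fluorobenzyl group at this position would begin to separate them.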